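Aziridinyl quinone series: shortening the alkoxyalkyl side chain

A few compounds are considered here, and "the series" means these few. Any claim that something is new, unique, unknown or untested is made for them only; others in the source may bear on it.

Going by the values given here, compound 1 `CCC(OC)C1=C(N2CC2)C(=O)C(C)=C(N2CC2)C1=O` gives the higher of the two numbers so far: in a functional assay on L1210 cells (Mus musculus), with a stated time of 1 days (a lower number here means a less potent compound, a higher number a more potent compound, by a factor of ten per unit of this negative logarithm), compound 1 gives 5.26. The other measured member, compound 2 `CCC1=C(N2CC2)C(=O)C(CC)=C(N2CC2)C1=O`, gives 4.94 in this assay, a gap beyond the usual scatter. Compound 3 `COCCC1=C(N2CC2)C(=O)C(C)=C(N2CC2)C1=O` is not yet measured; it differs from compound 1 by 2-methoxyethyl in place of 1-methoxypropyl on a double-bonded ring carbon. With no measured step of this kind in the series, only a small change is expected, if any beyond the scatter, and the estimated step is a number 0.16 log units lower from compound 1 to compound 3 (within the scatter). Compound 3 is expected to give about 5.1 in this assay, within 4.6 to 5.6.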

Compound 3, logarithm of the reciprocal of the active concentration, log(1/C): 5.19
Estimate against measurement, compound 3: 0.09 log units below; measured number inside the range.
By their numbers in this assay, from the lowest: compounds 2, 3 and 1 (each within the scatter of the next, the first and the last beyond it).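

In this assay, going by these compounds alone, 2-methoxyethyl in place of 1-methoxypropyl on the double-bonded ring carbon gives a number 0.07 log units lower from compound 1 to compound 3 (within the scatter), the first measured step at this position. Within this small pair, a chain of 4 heavy atoms and one of 5 heavy atoms, both carrying a methoxy group, cannot be told apart. No measured evidence on the origin of this result is available.

Going by these compounds, whether the methoxy oxygen matters at this position stays open. So does the outcome with a longer chain such as 3-methoxypropyl, or with an amine such as 2-(dimethylamino)ethyl, on the same ring carbon.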